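This account rests on a few compounds, and the source may have more. Where it says the series, first, only, none or still open, it means among the compounds named here.

In a functional assay on MV4-11 cells (Homo sapiens) for inhibition, with a stated time of 72 h (a lower number here means a stronger inhibitor, a higher number a weaker inhibitor), compound 1 (`CC(C)CN(Cc1ccc(C(=O)NO)cc1)S(=O)(=O)c1cc(F)c(F)c(F)c1F`) gives 520 nM and is the reference point for this account. Compound 2 (`CC(C)N(Cc1ccc(C(=O)NO)cn1)S(=O)(=O)c1cc(F)c(F)c(F)c1F`) gives 1000 nM and stands within the scatter of compound 1. Compound 3 (`COc1cc(C(=O)NO)ccc1CN(C(C)C)S(=O)(=O)c1cc(F)c(F)c(F)c1F`) gives 5660 nM and stands beyond the scatter of compound 1, with the higher number and so as the weaker inhibitor of that pair. Both differ from compound 1 in more than one place, so neither isolates a single structural change.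

Compound 4 (`O=C(NO)c1ccc(CN(C2CCCC2)S(=O)(=O)c2cc(F)c(F)c(F)c2F)cc1`) has not yet been measured and keeps the rest of the structure of compound 1. The one difference is cyclopentyl in place of isobutyl on a sulfonamide nitrogen in the place where the two structures part, with cyclopentyl in place of isobutyl on a sulfonamide nitrogen. Among the compounds with values here, no measured pair here shows what a change in that place does, so the expectation rests on compound 1 at 520 nM as its only anchor. In this assay no step beyond the scatter is expected, in either direction. The estimated step of a 1.2-fold lower number from compound 1 to compound 4 (0.06 log units; within the scatter) is expected to stay within the scatter. For compound 4 the estimated value is 450 nM with an expected range from 150 nM to 1400 nM once it is measured.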

Compound 4, half-maximal inhibitory concentration: 2710 nM
For compound 4 the middle estimate is 6.0-fold (0.78 log units) below the measured one, outside the stated range (above it).
By their numbers in this assay, from the lowest: compounds 1 and 2 (each within the scatter of the next); then compound 4; then compound 3.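

Within the data shown here, the swap of isobutyl for cyclopentyl on a sulfonamide nitrogen gives the first single-place comparison in this set, and in this assay it reads as a 5.2-fold higher number from compound 1 to compound 4 (0.72 log units; beyond the scatter) with the rest of the core of compound 1 unchanged. Among these compounds, this shows that the group at this position is not interchangeable: of this pair, compound 4, which carries the five-membered non-aromatic ring of carbon only, is the weaker inhibitor, and the earlier compounds, each differing from compound 1 in more than one place, could not show this. Nothing at hand gives a reason for the step.

The change alters the carbon count and introduces a ring at the same time, so this single pair cannot tell which of the two goes with the higher number. From the compounds shown here alone, whether an open chain such as n-pentyl, a smaller ring such as cyclobutyl or a larger ring such as cyclohexyl on that nitrogen would stand closer to compound 1 or to compound 4 remains open.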